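The source may hold more compounds than are shown below. What is called first, only, known or untested is meant among the compounds shown, and "the series" means these compounds.

Working notes on the thiosemicarbazide series.

Of the compounds shown here, three have been measured so far: compound 1 `Cc1cccc(/C(N)=N/NC(=S)N2CCSCC2)n1`, compound 2 `Cc1cccc(/C(N)=N/NC(=S)N2CCOCC2)n1` and compound 3 `Cc1cccc(/C(N)=N/NC(=S)N2CCCCC2)n1`. In a functional assay on HeLa cells (Homo sapiens) for cytotoxicity, read by MTT assay, with a stated time of 72 h, tested at 10 uM (a lower number here means less inhibition of growth, a higher number more inhibition of growth at the concentration tested), compound 1 gives 67.6%, compound 2 gives 85.4% and compound 3 gives 83.5%. Compound 3 stands second highest of the three numbers: its nearest neighbour is compound 2, within the scatter, and its furthest is compound 1, beyond the scatter. The two steps that leave compound 1 are a number 17.8 percentage points higher from compound 1 to compound 2 (beyond the scatter) and a number 15.9 percentage points higher from compound 1 to compound 3 (beyond the scatter), both modest; the step of a number 1.9 percentage points lower from compound 2 to compound 3 (within the scatter) lies within the scatter.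

The next compound, compound 4 `Cc1cccc(/C(N)=N/NC(=S)N2CCCC2)n1`, differs from compound 3 by pyrrolidin-1-yl in place of piperidin-1-yl on a thiocarbonyl carbon. Within the data shown here, no measured step changes ring size here; the only step that keeps the hetero atom at a nitrogen, from compound 2 to compound 3, shows no movement beyond the scatter, whereas the two steps from compound 1 show that replacing the ring on the thiocarbonyl carbon can shift this assay modestly. A small step is therefore expected, most likely none beyond the scatter, in either direction.

For compound 4 the expected value in this assay is 79%, with a range from 64% to 91%. The step from compound 3 to compound 4 is expected to be a number 4.5 percentage points lower from compound 3 to compound 4 (within the scatter).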

Compound 4, percent growth inhibition at one concentration: 79.2%
Compound 4: the middle estimate sits 0.2 percentage points below what was measured, and the stated range covers the measured number.
By their numbers in this assay, from the lowest: compound 1; then compounds 4, 3 and 2 (each within the scatter of the next).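

Among these compounds, the step from a six-membered to a five-membered ring on the thiocarbonyl carbon is the first change of ring size, and in this assay pyrrolidin-1-yl in place of piperidin-1-yl gives no movement beyond the scatter (a number 4.3 percentage points lower from compound 3 to compound 4 (within the scatter)). Pyrrolidin-1-yl also stays level with morpholin-4-yl (a number 6.2 percentage points lower from compound 2 to compound 4 (within the scatter)), so compound 2, compound 3 and compound 4 now form one group, across both ring size and a ring oxygen, while thiomorpholin-4-yl remains apart (a number 11.6 percentage points higher from compound 1 to compound 4 (beyond the scatter)), making compound 1 the least growth-inhibiting of the four at the concentration tested. No measurement shown bears on why compound 1 separates from the other three or why ring size leaves the number unmoved.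

The compounds shown leave open whether an open-chain dimethylamino group or a piperazin-1-yl ring on the thiocarbonyl carbon would stay with compound 2, compound 3 and compound 4 or fall with compound 1. They also leave open whether a different sulfur-bearing ring, such as thiazolidin-3-yl, would share the lower number of compound 1.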